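This account rests on a few compounds, and the source may have more. Where it says the series, first, only, none or still open, it means among the compounds named here.

Compound 1 `C[C@@H](Oc1cc2oc(=O)n(CCC(=O)O)c2cc1Cl)c1ccc(F)cn1` gives 2.51 nM in an assay for inhibition of kynurenine 3-monooxygenase (Homo sapiens), read by mass spectrometry, with a stated time of 1 h; on this read-out lower numbers stand for stronger inhibition and higher numbers for weaker inhibition.
Compound 2 `C[C@@H](Oc1cc2oc(=O)n(CCC(=O)O)c2cc1Cl)c1ncco1` gives 3.16 nM in this assay.

Of these two numbers compound 2 has the higher one, and its nearest neighbour is compound 1, separated by a 1.3-fold higher number from compound 1 to compound 2 (0.10 log units; within the scatter). The two compounds share one core and differ only in the aromatic group placed on a saturated chain carbon bound to an oxygen on an aromatic ring and a saturated chain carbon.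

Compound 3 `Cc1cccc([C@@H](C)Oc2cc3oc(=O)n(CCC(=O)O)c3cc2Cl)n1` has not yet been measured. It differs from compound 2 at that same place: 6-methylpyridin-2-yl in place of 1,3-oxazol-2-yl on a saturated chain carbon bound to an oxygen on an aromatic ring and a saturated chain carbon.

For the measured compounds named here, only one measured step bears on this change, the swap of the aromatic group from compound 1 to compound 2, and that step stayed within the scatter. A six-membered ring with one nitrogen enters again, as in compound 1, so for compound 3 the expected step is a 1.3-fold lower number from compound 2 to compound 3 (0.10 log units; within the scatter), with no shift beyond the scatter anticipated. The estimate for compound 3 in this assay is therefore 2.5 nM, within a range of 1 nM to 6.3 nM.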

Compound 3, half-maximal inhibitory concentration: 5.01 nM
The estimate for compound 3 lay 2.0-fold (0.30 log units) below the measured number, and the stated range covers the measured number.
By their numbers in this assay, from the lowest: compounds 1, 2 and 3 (each within the scatter of the next).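

In this assay, a third aromatic group on this saturated chain carbon gives a number that stays within the scatter of both earlier ones: replacing 1,3-oxazol-2-yl gives a 1.6-fold higher number from compound 2 to compound 3 (0.20 log units; within the scatter), and replacing 5-fluoropyridin-2-yl gives a 2.0-fold higher number from compound 1 to compound 3 (0.30 log units; within the scatter). This position therefore accepts 6-methylpyridin-2-yl, with 7 heavy atoms, as well as the five-membered 1,3-oxazol-2-yl, with 5, and the assay does not separate the three compounds. Nothing available explains why these numbers stay so close.

From the compounds shown here alone, all three groups are aromatic rings containing nitrogen, so it remains open whether a plain phenyl ring or a saturated cyclohexyl group would stay within the same scatter. The compounds also leave open what an amide in place of the carboxylic acid would do to the number.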